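Swapping chloro for sulfanyl on a weak nucleoside inhibitor

This account rests on a few compounds, and the source may have more. Where it says the series, first, only, none or still open, it means among the compounds named here.

Measured in a functional assay on MT4 cells (Homo sapiens) for inhibition; on this read-out lower numbers stand for stronger inhibition and higher numbers for weaker inhibition:
compound 1 `C=C1[C@@H](O)[C@H](n2cnc3c(N(C)C)nc(N)nc32)O[C@@H]1CO`: > 500000 nM (a limit of the assay)
compound 2 `C=C1[C@H](n2cnc3c(Cl)nc(N)nc32)O[C@H](CO)[C@H]1O`: 176000 nM

Among the measured compounds shown here, only two compounds have been measured so far, and they give little to work from. For the measured compounds named here, compound 2 gives the only actual number in this assay at 176000 nM. The other result, that of compound 1, is a limit and not a number.

The next compound to be tested is compound 3 `C=C1[C@H](n2cnc3c(S)nc(N)nc32)O[C@H](CO)[C@H]1O`. It has sulfanyl in place of chloro on an aromatic carbon and is otherwise the same as compound 2.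

Going by the values given here, no measured pair covers this exchange, so the expectation is anchored only on compound 2 at 176000 nM. A moderate step toward lower numbers in this assay is expected, beyond the usual scatter, although its size is poorly constrained and a second limit remains possible. The estimated change is a 3.5-fold lower number from compound 2 to compound 3 (0.55 log units; beyond the scatter). For compound 3 the expected value is 50000 nM, with an estimated range from 5000 nM to 400000 nM.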

Compound 3, half-maximal inhibitory concentration: 480 nM
Compound 3: the middle estimate sits 100-fold (2.02 log units) above what was measured; measured number below the stated range.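

In this assay, the exchange of chloro for sulfanyl on this aromatic carbon, next to the ring nitrogen, gives a 370-fold lower number from compound 2 to compound 3 (2.56 log units; beyond the scatter), which shows that this position responds very strongly to a change of one heavy atom. Among the compounds shown here, this is the first step that can be read, and it turns a weak number into a far stronger one while the rest of the structure stays the same. The exchange also adds a hydrogen-bond donor and a hydrogen-bond acceptor to the count, but this single step cannot show whether either of them, the sulfur atom itself or something else accounts for its size, and compound 1 gives only a limit, which offers no comparison with this step: the limit of > 500000 nM in this assay, at which 1 of the 3 values shown sits.

On these data alone, what stays open is whether the strong response belongs to sulfanyl alone or would also appear with a hydroxyl, a methylsulfanyl or a primary amino group on the same carbon. As far as these compounds go, it is also open whether sulfanyl would bring a similar step on another core, since this exchange is seen only once.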